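The source may report more compounds than this note shows. Statements on the series, on what has been measured and on what is new or still open speak of the compounds shown alone.

In an ADME assay on HCT-116 cells (Homo sapiens) for cytotoxicity, read by CellTiter-Glo, with a stated time of 72 h (on this read-out higher numbers stand for weaker inhibition and lower numbers for stronger inhibition), compound 1 `CC1CCN(C2CCN(S(=O)(=O)c3cccnc3)CC2)CC1` gives > 10000 nM as a limit and not a number. Compound 2 `CC1CCN(C2CCN(S(=O)(=O)c3nccn3C)CC2)CC1` gives > 10000 nM and this too is only a limit. For the measured compounds named here, the only measured step is a step that the two limits leave unreadable from compound 1 to compound 2 and the evidence, (the limit of > 10000 nM in this assay, at which 2 of the 2 values shown sit), offers no size to carry forward. Compound 3 `CC1CCN(C2CCN(S(=O)(=O)c3cccc(Cl)c3)CC2)CC1` differs from compound 2 as follows 3-chlorophenyl in place of 1-methyl-1H-imidazol-2-yl on a sulfonyl sulfur with 3-chlorophenyl in place of 1-methyl-1H-imidazol-2-yl on a sulfonyl sulfur. Going by the values given here, no step of definite size or direction can be expected in this assay on this basis. The estimated change is a step that the limit leaves unreadable from compound 2 to compound 3 and it rests on very little. Compound 3 is expected at 15000 nM within an estimated range from 5000 nM to 40000 nM and may again yield only a limit.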

Compound 3, half-maximal inhibitory concentration: > 5000 nM
Compound 3 was reported as a limit; the forecaster's own chance of this, stated with the estimate: 70%; the middle value lies beyond the limit too.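

In this assay compound 3 gives > 5000 nM, a limit and not a number. For the compounds shown here, no step from compound 1 or compound 2 to compound 3 can be read. The compounds shown leave open whether changing the group on the sulfonyl sulfur alters the result at all.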